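Dimethoxypyrimidine in place of the isoxazole on a sulfonamide

The compounds below may be only part of what the source reports. "The series", "measured", "known", "first", "only" and "open" are said of these compounds alone.

Compound 1 `Cc1cc(NS(=O)(=O)c2ccc(N/C(S)=N\c3ccnc4cc(C(F)(F)F)ccc34)cc2)on1` was tested in a functional assay on MDA-MB-231 cells (Homo sapiens) for antiproliferative activity, read by sulforhodamine B assay, with a stated time of 48 h (a lower number here means a stronger inhibitor, a higher number a weaker inhibitor), where compound 1 gives 80300 nM. Going by the values given here, the only other measured compound, compound 2 `Cc1cc(C)nc(NS(=O)(=O)c2ccc(N/C(S)=N\c3ccnc4cc(C(F)(F)F)ccc34)cc2)n1`, gives 52900 nM; these two values lie within the scatter of each other, so compound 1 cannot be told apart from compound 2. Among the compounds with values here, the step of a 1.5-fold lower number from compound 1 to compound 2 (0.18 log units; within the scatter) swaps the ring on the sulfonamide nitrogen and is the one measured step that bears on compound 3 `COc1ncnc(NS(=O)(=O)c2ccc(N/C(S)=N\c3ccnc4cc(C(F)(F)F)ccc34)cc2)c1OC`, which differs from compound 1 by 5,6-dimethoxypyrimidin-4-yl in place of 3-methyl-1,2-oxazol-5-yl on a sulfonamide nitrogen. Because that step a 1.5-fold lower number from compound 1 to compound 2 (0.18 log units; within the scatter) stayed within the scatter, the step of a 1.2-fold lower number from compound 1 to compound 3 (0.09 log units; within the scatter) is expected to stay within it as well. Compound 3 is estimated at 65000 nM, with a range from 20000 nM to 200000 nM.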

Compound 3, half-maximal inhibitory concentration: 83000 nM
Beside the measured number, compound 3's estimate is 1.3-fold (0.11 log units) below it; low and high end bracket the measured number.
By their numbers in this assay, from the lowest: compounds 2, 1 and 3 (each within the scatter of the next).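

In this assay, 5,6-dimethoxypyrimidin-4-yl on the sulfonamide nitrogen gives a 1.0-fold higher number from compound 1 to compound 3 (0.01 log units; within the scatter), and against the other pyrimidine it gives a 1.6-fold higher number from compound 2 to compound 3 (0.20 log units; within the scatter). Going by these compounds alone, this position has therefore taken a bigger group with more hydrogen-bond acceptors, and two differently substituted pyrimidines, with no step leaving the scatter. Nothing available explains this flat result. The compounds shown carry only aromatic rings on this nitrogen, so whether an open chain ending in an amine or a carboxylic acid would shift the number remains open.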